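Oral bioavailability in the series: from benzyl to heteroaryl on ring nitrogen

The compounds below may be only part of what the source reports. "The series", "measured", "known", "first", "only" and "open" are said of these compounds alone.

Compound 1 `Cc1cccc(F)c1CN1CCc2cc(-c3c(C)nc(C)c([C@H](OC(C)(C)C)C(=O)O)c3N3CCC(C)(C)CC3)ccc2C1` gives the higher of the two numbers measured in an ADME assay on the whole organism (Rattus norvegicus, strain Sprague-Dawley) for pharmacokinetics, read by LC-MS, at a dose of 5 mg/kg by the oral route (a higher number here means that a larger share of the oral dose reaches the circulation, a lower number that a smaller share of the oral dose reaches the circulation), at 70%; its nearest neighbour is compound 2 `Cc1nc(C)c([C@H](OC(C)(C)C)C(=O)O)c(N2CCC(C)(C)CC2)c1-c1ccc2c(c1)CCN(Cc1cccc(F)c1F)C2`, which in this assay gives 50%. Among the measured compounds shown here, the one measured step is a number 20 percentage points lower from compound 1 to compound 2 (beyond the scatter). Its change sits on the saturated chain carbon bound to the amine nitrogen in a ring, so a change at this part of the shared core can move the read-out beyond the scatter.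

Compound 3 `Cc1nc(C)c([C@H](OC(C)(C)C)C(=O)O)c(N2CCC(C)(C)CC2)c1-c1ccc2c(c1)CCN(c1nc3cnccc3s1)C2` is not yet measured. It differs from compound 1 by a group of 9 heavy atoms (6 carbon, 2 nitrogen, 1 sulfur; one five-membered aromatic ring with 2 hetero atoms, one six-membered aromatic ring with 1 hetero atom) in place of a group of 9 heavy atoms (8 carbon, 1 fluorine; one six-membered aromatic ring of carbon only), on an amine nitrogen in a ring. For the measured compounds named here, this is a larger change than the one from compound 1 to compound 2: the benzyl group leaves altogether and a group with three hydrogen-bond acceptors enters directly on the amine nitrogen in a ring. Going by the values given here, no measured step covers such a change, so the direction is uncertain; the only guidance is that the step of a number 20 percentage points lower from compound 1 to compound 2 (beyond the scatter) was modest and downward. A downward step of similar or somewhat larger size is therefore expected, a number 25 percentage points lower from compound 1 to compound 3 (beyond the scatter), with a wide range. Compound 3 is estimated at 45%, between 20% and 70%.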

Compound 3, oral bioavailability: > 100%
Compound 3 was reported as a limit (the forecaster's own chance of this, stated with the estimate: 0%); at least 55 percentage points between middle value and limit.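

Working notes on the amine nitrogen in a ring: in this assay, the only earlier step at this position ran downward, whereas replacing the 2-fluoro-6-methylbenzyl group with a group made of a five-membered aromatic ring with 2 hetero atoms and a six-membered aromatic ring with 1 hetero atom gives a number at least 30 percentage points higher from compound 1 to compound 3 (beyond the scatter), and the comparison with the difluorinated analogue gives a number at least 50 percentage points higher from compound 2 to compound 3 (beyond the scatter). The read-out at this position can therefore move in both directions beyond the scatter, and the benzyl group is not needed for a high value within these three compounds. The result for compound 3 is a limit and not a number: the limit of > 100% in this assay, at which 1 of the 3 values shown sits.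

The compounds shown do not separate the loss of the saturated chain carbon from the arrival of the new ring group, since both occur in the same step; a plain phenyl group directly on the amine nitrogen, or the new ring group attached through a methylene, would divide the two. As far as these compounds go, the separate contributions of the sulfur and of each ring nitrogen also remain open.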